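Quinoline cinnamamides: shortening the alkyl group in compound 4

This account rests on a few compounds, and the source may have more. Where it says the series, first, only, none or still open, it means among the compounds named here.

Compound 1 `CC(C)(C)c1cc(N)c2cc(NC(=O)/C=C/c3ccc(C(F)(F)F)cc3)ccc2n1` gives 29 nM in a functional assay on HEK293 cells for activation of melanin-concentrating hormone receptor 1 (Homo sapiens), read by inositol phosphate accumulation (a higher number here means that more compound is needed for the effect, a lower number that less compound is needed), the lowest number among the three measured compounds. Among the measured compounds shown here, compound 2 `CCCc1cc(NC2CCC2)c2cc(NC(=O)/C=C/c3ccc(C(F)(F)F)cc3)ccc2n1` gives 270 nM and compound 3 `CCCc1cc(N)c2cc(NC(=O)/C=C/c3ccccc3Cl)ccc2n1` gives 500 nM in this assay; both carry a propyl group and further changes elsewhere, so no single step from compound 1 can be read from them. Compound 4 `CCc1cc(N)c2cc(NC(=O)/C=C/c3ccc(C(F)(F)F)cc3)ccc2n1` is not yet measured. It differs from compound 1 by ethyl in place of tert-butyl on an aromatic carbon. For the measured compounds named here, with no directly comparable step, a moderate rise in the number, beyond the scatter, is expected, since the only compounds without tert-butyl, compound 2 at 270 nM and compound 3 at 500 nM, sit higher. Compound 4 is thus estimated at 80 nM in this assay, within 25 nM to 250 nM, a step of a 2.8-fold higher number from compound 1 to compound 4 (0.44 log units; beyond the scatter) expected from compound 1.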

Compound 4, half-maximal effective concentration: 110 nM
Compound 4: the middle estimate sits 1.4-fold (0.14 log units) below what was measured; the range from low to high includes it.
By their numbers in this assay, from the lowest: compound 1; then compound 4; then compounds 2 and 3 (each within the scatter of the next).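

In this assay, among the compounds shown here, ethyl in place of tert-butyl on this aromatic carbon next to the ring nitrogen gives a 3.8-fold higher number from compound 1 to compound 4 (0.58 log units; beyond the scatter) as the first step read at a single place. The step is modest, so this position keeps activity without tert-butyl, although compound 1 retains the lower number. No measurement here accounts for the size of this step.

Steps to compound 2 and compound 3 cannot be read, as each differs from compound 1 and compound 4 in more than one place. Going by these compounds, how methyl or a cyclopropyl ring would read at this position remains open.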